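Swapping the tert-butyl of a carbamate for phenyl

The source may report more compounds than this note shows. Statements on the series, on what has been measured and on what is new or still open speak of the compounds shown alone.

In an assay for displacement of a labelled ligand from metabotropic glutamate receptor 5 (Rattus norvegicus) (on this read-out lower numbers stand for stronger inhibition and higher numbers for weaker inhibition), compound 2 `CC(C)(C)OC(=O)N1CC=C(C#Cc2ccccn2)CC1` gives 20 nM. Among the three measured compounds it sits second highest: compound 1 `C(#Cc1ccccn1)C1=CCCC1` gives 10 nM, within the scatter of compound 2, while compound 3 `C(#Cc1ccccn1)C1=CCNCC1` gives 3400 nM. Compound 4 `O=C(Oc1ccccc1)N1CC=C(C#Cc2ccccn2)CC1` differs from compound 2 by phenyl in place of tert-butyl on an oxygen next to a carbonyl group. Going by the values given here, the only measured step that touches this part of the molecule is a 170-fold higher number from compound 2 to compound 3 (2.23 log units; beyond the scatter), where the whole tert-butoxycarbonyl group gave way to hydrogen. Compound 4 keeps the carbonyl and its oxygen and alters only the group on that oxygen, so a much smaller shift is expected, at most a modest move toward a higher number. Compound 4 is therefore estimated at 35 nM, with a range of 8 nM to 150 nM. The expected step is a 1.8-fold higher number from compound 2 to compound 4 (0.24 log units; within the scatter).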

Compound 4, inhibition constant: 171 nM
For compound 4 the middle estimate is 4.9-fold (0.69 log units) below the measured one; the measured number lies above the stated range.
By their numbers in this assay, from the lowest: compounds 1 and 2 (each within the scatter of the next); then compound 4; then compound 3.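

In this assay, phenyl in place of tert-butyl gives an 8.6-fold higher number from compound 2 to compound 4 (0.93 log units; beyond the scatter), so the group on that oxygen matters in its own right, even with the carbonyl kept. That step is still smaller than a 170-fold higher number from compound 2 to compound 3 (2.23 log units; beyond the scatter), where the whole tert-butoxycarbonyl group leaves. No measurement here explains the difference between tert-butyl and phenyl. Open, on these data alone, is whether the aromatic ring or some other feature of phenyl drives the shift: cyclohexyl on the same oxygen would separate these, while methyl would show how a much smaller group fares.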